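A few compounds are considered here, and "the series" means these few. Any claim that something is new, unique, unknown or untested is made for them only; others in the source may bear on it.

Compound 1 `CNC(=O)[C@@]12C[C@@H]1[C@@H](n1cnc3c(NC)nc(C#Cc4ccccc4)nc31)[C@H](O)[C@@H]2O`: 18%
Compound 2 `CNC(=O)[C@@]12C[C@@H]1[C@@H](n1cnc3c(NC)nc(C#Cc4ccc(CO)cc4)nc31)[C@H](O)[C@@H]2O`: 16%

In an assay on CHO cells for displacement of a labelled ligand from adenosine receptor A1 (Homo sapiens), read by scintillation counting, with a stated time of 60 min, tested at 10 uM (a lower number here means less inhibition, a higher number more inhibition at the concentration tested (going by the name of the read-out)), compound 2 gives 16%, and compound 1 stands beside it, the step of a number 2 percentage points lower from compound 1 to compound 2 (within the scatter) lying within the scatter. Compound 3 `CNC(=O)[C@@]12C[C@@H]1[C@@H](n1cnc3c(NC)nc(C#Cc4cc5ccccc5o4)nc31)[C@H](O)[C@@H]2O` differs from compound 2 in one place: 1-benzofuran-2-yl in place of 4-(hydroxymethyl)phenyl on a triple-bonded carbon. Going by the values given here, the only measured step, a number 2 percentage points lower from compound 1 to compound 2 (within the scatter), concerns a hydroxymethyl group alone and says little about exchanging the whole ring, but it was small. No step beyond the scatter is therefore expected, the step of a number 4 percentage points higher from compound 2 to compound 3 (within the scatter) being the estimate. For compound 3 the expected value in this assay is 20%, within 5% to 40%.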

Compound 3, a percentage reported as inhibition, at one concentration (the size of the read-out at that concentration, not a potency): 13%
Beside the measured number, compound 3's estimate is 7 percentage points above it, within the range that was stated.
By their numbers in this assay, from the lowest: compounds 3, 2 and 1 (each within the scatter of the next).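

In this assay a second, fused ring on the triple-bonded carbon leaves the reading within the scatter: a number 3 percentage points lower from compound 2 to compound 3 (within the scatter) and a number 5 percentage points lower from compound 1 to compound 3 (within the scatter) are both seen when 1-benzofuran-2-yl replaces a single six-membered ring. So this position has now been varied in the ring itself and not only in a hydroxymethyl group, still with no step beyond the scatter. No measurement here offers an explanation for these readings. As far as these compounds go, whether a ring carrying an amine or a carboxylic acid, or a longer alkyl chain, on this carbon would give a step beyond the scatter stays open.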